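A few compounds are considered here, and "the series" means these few. Any claim that something is new, unique, unknown or untested is made for them only; others in the source may bear on it.

Measured so far:
compound 1 `CCC(=O)Oc1cc(/C=C/C(=O)c2ccc(OC)c3c2OC(C)(C)C=C3)ccc1OC` with 160 nM;
compound 2 `COc1ccc(/C=C/C(=O)c2ccc(OC)c3c2OC(C)(C)C=C3)cc1OC(=O)C1CC1` with 410 nM;
compound 3 `COc1cccc(C(=O)Oc2cc(/C=C/C(=O)c3ccc(OC)c4c3OC(C)(C)C=C4)ccc2OC)c1` with 790 nM.

All three were tested in a functional assay on K562 cells (Homo sapiens) for cytotoxicity, read by MTT assay; a lower number here means a stronger inhibitor, a higher number a weaker inhibitor. Among these three numbers compound 1 gives the lowest; compound 2 lies nearest to it, a 2.6-fold higher number from compound 1 to compound 2 (0.41 log units; beyond the scatter), and compound 3 lies furthest, a 4.9-fold higher number from compound 1 to compound 3 (0.69 log units; beyond the scatter). Between compound 2 and compound 3 the step is a 1.9-fold higher number from compound 2 to compound 3 (0.28 log units; within the scatter).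

The unmeasured compound 4 `COc1ccc(/C=C/C(=O)Oc2cc(/C=C/C(=O)c3ccc(OC)c4c3OC(C)(C)C=C4)ccc2OC)cc1` is reached from compound 1 by a single change: 2-(4-methoxyphenyl)ethenyl in place of ethyl on a carbonyl carbon. The two measured steps that leave the same ethyl group on that carbonyl carbon both run upward: to cyclopropyl, a 2.6-fold higher number from compound 1 to compound 2 (0.41 log units; beyond the scatter), and to 3-methoxyphenyl, a 4.9-fold higher number from compound 1 to compound 3 (0.69 log units; beyond the scatter). The group entering in compound 4 is larger again than either, and carries an aromatic ring as the 3-methoxyphenyl of compound 3 does, so a higher number than compound 1 is expected in this assay, of a size comparable to the step to compound 3 or somewhat beyond it. On that basis compound 4 is estimated at 800 nM, with a range from 300 nM to 2200 nM, which corresponds to an expected step of a 5.0-fold higher number from compound 1 to compound 4 (0.70 log units; beyond the scatter).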

Compound 4, half-maximal inhibitory concentration: 380 nM
Estimate against measurement, compound 4: 2.1-fold (0.32 log units) above, and the stated range covers the measured number.
By their numbers in this assay, from the lowest: compound 1; then compounds 4, 2 and 3 (each within the scatter of the next, the first and the last beyond it).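

In this assay the 2-(4-methoxyphenyl)ethenyl group on this carbonyl carbon still gives a higher number than the ethyl of compound 1 (a 2.4-fold higher number from compound 1 to compound 4 (0.38 log units; beyond the scatter)), but the rise is not ordered by the size of the group. Compound 4, with its aromatic ring held out on a double bond, gives a lower number than the directly attached 3-methoxyphenyl (a 2.1-fold lower number from compound 3 to compound 4 (0.32 log units; beyond the scatter)) and cannot be told apart from the much smaller cyclopropyl (a 1.1-fold lower number from compound 2 to compound 4 (0.03 log units; within the scatter)), so among these four compounds a large group with an aromatic ring at this place is compatible with a number in the range of the cyclopropyl compound. Nothing in the data at hand accounts for this difference between the two aromatic groups.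

Still open, going by these compounds, is whether the double bond itself matters, which a saturated 2-(4-methoxyphenyl)ethyl group at the same place would test, and whether the methoxy group on the ring does, which an unsubstituted styryl group would test. The compounds shown also leave unsettled how a methyl, a longer chain such as butyl, or a chain ending in an amine or a carboxylic acid would read here.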